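The source may report more compounds than this note shows. Statements on the series, on what has been measured and on what is new or still open speak of the compounds shown alone.

Measured compounds and their numbers in a functional assay on SW 1116 cells (Homo sapiens) for cytotoxicity, read by MTT assay, with a stated time of 48 h; a higher number here means a weaker inhibitor, a lower number a stronger inhibitor:
- compound 1 `O=C(CSc1nnc(-c2ccncc2)o1)N/N=C/c1ccc(Cl)cc1` gives 17000 nM
- compound 2 `O=C(CSc1nnc(-c2ccncc2)o1)N/N=C/c1ccc(O)cc1` gives 12200 nM
- compound 3 `O=C(CSc1nnc(-c2ccncc2)o1)N/N=C/c1cc(Cl)cc(Cl)c1O` gives 5030 nM

Compound 3 stands at the lowest number of the three in this assay; the step of a 2.4-fold lower number from compound 2 to compound 3 (0.38 log units; beyond the scatter) is modest but beyond the scatter, and the step of a 3.4-fold lower number from compound 1 to compound 3 (0.53 log units; beyond the scatter) is somewhat larger, so compound 3 is the strongest inhibitor among the measured compounds.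

Compound 4 `O=C(CSc1nnc(-c2ccncc2)o1)N/N=C/c1ccc(O)c(O)c1` has not yet been measured. Its change from compound 3 is 3,4-dihydroxyphenyl in place of 3,5-dichloro-2-hydroxyphenyl on a carbon with a double bond to nitrogen. Among the measured compounds shown here, two measured steps bear on it. The step of a 1.4-fold lower number from compound 1 to compound 2 (0.14 log units; within the scatter) shows that exchanging a chloro for a hydroxy on the aromatic carbon barely moves the number. The step of a 2.4-fold lower number from compound 2 to compound 3 (0.38 log units; beyond the scatter) shows that putting in the 3,5-dichloro-2-hydroxyphenyl in place of 4-hydroxyphenyl lowers the number modestly. Compound 4 undoes that dichloro-bearing ring and returns to a hydroxy-substituted ring, so a modest rise in the number, back toward the number of compound 2, is expected; nothing measured speaks to the second hydroxy. The expected step is a 1.9-fold higher number from compound 3 to compound 4 (0.28 log units; within the scatter). Compound 4 is therefore estimated at 9500 nM in this assay, with a range from 4000 nM to 22000 nM.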

Compound 4, half-maximal inhibitory concentration: 1540 nM
Compound 4: middle estimate off by 6.2-fold (0.79 log units), on the high side, and the stated range ends above it.
By their numbers in this assay, from the lowest: compound 4; then compound 3; then compounds 2 and 1 (each within the scatter of the next).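

In this assay, the step of a 7.9-fold lower number from compound 2 to compound 4 (0.90 log units; beyond the scatter) comes from turning 4-hydroxyphenyl into 3,4-dihydroxyphenyl, so this ring position can move the number far more than the chloro-to-hydroxy exchange a 1.4-fold lower number from compound 1 to compound 2 (0.14 log units; within the scatter) suggested, which stayed within the scatter. The chlorines of compound 3 are not needed for the lowest number in the series: 3,4-dihydroxyphenyl on the carbon with a double bond to nitrogen gives a 3.3-fold lower number from compound 3 to compound 4 (0.51 log units; beyond the scatter) and also an 11-fold lower number from compound 1 to compound 4 (1.04 log units; beyond the scatter) and so makes compound 4 the strongest inhibitor of the four, while no measured evidence is available to explain this gain.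

Still open, going by these compounds, is whether the gain depends on both hydroxy groups of the 3,4-dihydroxyphenyl ring, a question that a methoxy or an amine in place of either hydroxy on the core of compound 4 would address. Also open, on these data alone, is whether the order of compound 4 and compound 3 holds in cell lines other than this one, and whether a lower number here reflects anything more specific than general cytotoxicity.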